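The source may report more compounds than this note shows. Statements on the series, on what has been measured and on what is new or still open speak of the compounds shown alone.

Working notes on the series, all on the shared core. In an ADME assay on Vero cells (Chlorocebus sabaeus) for cytotoxicity, read by MTT assay, with a stated time of 72 h (on this read-out higher numbers stand for lower toxicity in this test and lower numbers for higher toxicity in this test), compound 1 (`C[C@]1(CN2CCc3nc(-c4ccc(OC(F)(F)F)cc4)ccc3C2)Cn2cc([N+](=O)[O-])nc2O1`) has "not determined" (no result reported) as its entry. In this assay compound 2 (`C[C@]1(CN2CCc3nc(C4CC4)ccc3C2)Cn2cc([N+](=O)[O-])nc2O1`) likewise has "not determined" (no result reported) as its entry. In this assay compound 3 (`C[C@]1(CN2CCc3nc(-c4ccc(Cl)c(F)c4)ccc3C2)Cn2cc([N+](=O)[O-])nc2O1`) gives > 32 ug/mL as its result, and this is a limit of the assay and not a number. For the measured compounds named here, the record for the series therefore holds one result of this kind (the limit of > 32 ug/mL in this assay, at which 1 of the 3 values shown sits) and no measured step between compounds.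

Compound 4 (`C[C@]1(CN2CCc3nc(-c4cc(F)cc(Cl)c4)ccc3C2)Cn2cc([N+](=O)[O-])nc2O1`) has the same atoms as compound 3, joined differently: 3-chloro-5-fluorophenyl in place of 4-chloro-3-fluorophenyl on an aromatic carbon, next to the ring nitrogen (3-chloro-5-fluorophenyl in place of 4-chloro-3-fluorophenyl on an aromatic carbon). Going by the values given here, with no measured step to draw on, the expectation rests on compound 3 alone, whose > 32 ug/mL result is a limit. The expected step that the limit leaves unreadable from compound 3 to compound 4 is none beyond the usual scatter of this assay in either direction. A report of only a limit is also the likeliest expected outcome for compound 4. For compound 4 the estimated value is 40 ug/mL with an expected range of 20 ug/mL to 80 ug/mL around it.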

Compound 4, half-maximal cytotoxic concentration: > 32 ug/mL
Compound 4: a limit, no number (the forecaster's own chance of this, stated with the estimate: 80%); the middle value lies beyond the limit too.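

For the compounds shown here, compound 3 and compound 4 both stand as limits and not numbers in this assay, so no step between them can be read: the limit of > 32 ug/mL in this assay, at which 2 of the 4 values shown sit.

The compounds shown leave open whether 3-chloro-5-fluorophenyl and 4-chloro-3-fluorophenyl differ at all on this read-out, with neither half-maximal cytotoxic concentration available as a number.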